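The source may hold more compounds than are shown below. What is called first, only, known or untested is meant among the compounds shown, and "the series" means these compounds.

Measured so far:
Compound 1, `COc1ccc(-c2csc(N)c2C(=O)OCc2ccccc2)cc1OC`, gives 100% in an assay on isolated protein for inhibition of protein kinase C zeta type (Homo sapiens), with stated times of 1 h and 2.5 min, tested at 30 uM; on this read-out lower numbers stand for less inhibition and higher numbers for more inhibition at the one concentration tested (going by the name of the read-out).
Compound 2, `CCOC(=O)c1c(-c2cccc(NC(C)=O)c2)csc1N`, gives 89% in this assay.
Compound 3, `CCOC(=O)c1c(-c2cccc(C(F)(F)F)c2)csc1N`, gives 30% in this assay.

Compound 3 stands lowest of the three: compound 2 lies higher by a step beyond the scatter, and compound 1 lies further above still. Within the data shown here, the one measured step that changes a single place is the one from compound 2 to compound 3, in which trifluoromethyl took the place of acetamido on an aromatic carbon, and it gave a number 59 percentage points lower from compound 2 to compound 3 (beyond the scatter).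

Compound 4, `CCOC(=O)c1c(-c2cccc(C#N)c2)csc1N`, differs from compound 3 in one place: cyano in place of trifluoromethyl on an aromatic carbon.

Among the measured compounds shown here, no measured step swaps a cyano group in or out, so the direction of this change has to be read from the neighbours. Both groups that gave higher readings, acetamido in compound 2 and the methoxy pair in compound 1, carry at least one hydrogen-bond acceptor; trifluoromethyl in compound 3 carries none, and cyano brings one back, as the count shows. Compound 4 is therefore expected to sit somewhat above compound 3, by a step of about a number 15 percentage points higher from compound 3 to compound 4 (beyond the scatter), though smaller than the drop seen from compound 2 to compound 3. The estimate for compound 4 in this assay is 45%, within a range from 15% to 80%.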

Compound 4, a percentage reported as inhibition, at one concentration (the size of the read-out at that concentration, not a potency): 32%
For compound 4 the middle estimate is 13 percentage points above the measured one, and the stated range covers the measured number.
By their numbers in this assay, from the lowest: compounds 3 and 4 (each within the scatter of the next); then compound 2; then compound 1.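

Placing cyano on this aromatic carbon in place of trifluoromethyl gave a number 2 percentage points higher from compound 3 to compound 4 (within the scatter) in this assay, so this assay does not separate the two groups, even though cyano carries a hydrogen-bond acceptor and trifluoromethyl carries none. Adding that single acceptor is therefore not enough on its own to bring back the higher reading, and the change from acetamido to cyano gave a number 57 percentage points lower from compound 2 to compound 4 (beyond the scatter), which means that a second replacement for acetamido now also reads far lower, so the high reading at this position is so far seen only with acetamido among these ethyl esters. No measurement given here explains why acetamido stands apart from the other two groups.

From the compounds shown here alone, it remains open which part of acetamido matters, the amide hydrogen, the carbonyl or the whole group, and an amine or a methanesulfonamide on the same carbon would help to separate these possibilities. It is also unclear whether a longer acyl chain, such as propionamido, or a carboxylic acid at this place would keep the reading of compound 2 at 89%.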